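Swapping piperidin-1-yl for (4-methoxyphenyl)amino on the shared core

The source may hold more compounds than are shown below. What is called first, only, known or untested is meant among the compounds shown, and "the series" means these compounds.

Compound 1 `O=C1C(NC2CCCC2)=CC(=O)c2c1nc1n2[C@H]2OC[C@@H](O)[C@H]2OC1` - > 16000 nM - a limit
Compound 2 `O=C1C(Nc2ccc(Br)cc2)=CC(=O)c2c1nc1n2[C@H]2OC[C@@H](O)[C@H]2OC1` - 1980 nM - a number
Compound 3 `O=C1C(N2CCCCC2)=CC(=O)c2c1nc1n2[C@H]2OC[C@@H](O)[C@H]2OC1` - > 8000 nM - a limit

In a functional assay on ECa-109 cells for inhibition, with ECa-109 cell line (Homo sapiens) as the target, read by sulforhodamine B assay (on this read-out lower numbers stand for stronger inhibition and higher numbers for weaker inhibition), compound 3 reads > 8000 nM as a limit and not as a number. Compound 1 also reads > 16000 nM as a limit. Among the compounds with values here, compound 2 is the only one of the three with a number, 1980 nM in this assay so far.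

The next change puts (4-methoxyphenyl)amino in place of piperidin-1-yl on a double-bonded ring carbon, which gives compound 4 `COc1ccc(NC2=CC(=O)c3c(nc4n3[C@H]3OC[C@@H](O)[C@H]3OC4)C2=O)cc1` ((4-methoxyphenyl)amino in place of piperidin-1-yl on a double-bonded ring carbon). Within the data shown here, two measured steps bear on it. The closer one is an at least 4.0-fold higher number from compound 2 to compound 3 (0.60 log units; beyond the scatter) when piperidin-1-yl replaces (4-bromophenyl)amino, and the change now in view runs the opposite way. The other is an at least 8.0-fold lower number from compound 1 to compound 2 (0.90 log units; beyond the scatter) when 4-bromophenyl replaces cyclopentyl on an amine nitrogen. Among the measured compounds shown here, no measured step compares the 4-methoxyphenyl and 4-bromophenyl groups, so compound 2 serves only as a guide.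

A lower number is therefore expected, with the estimated change being an at least 2.6-fold lower number from compound 3 to compound 4 (0.42 log units; beyond the scatter) in this assay on this reasoning. For compound 4 the estimate is 3000 nM with a range from 1000 nM to 9000 nM as the expected span.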

Compound 4, half-maximal inhibitory concentration: 3410 nM
Compound 4: middle estimate off by 1.1-fold (0.06 log units), on the low side; measured number inside the range.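

In this assay, (4-methoxyphenyl)amino on this double-bonded ring carbon gives a measured number where piperidin-1-yl gave only a limit, with an at least 2.3-fold lower number from compound 3 to compound 4 (0.37 log units; beyond the scatter). Methoxy in place of bromo on the aromatic carbon leaves the reading within the usual scatter, with a 1.7-fold higher number from compound 2 to compound 4 (0.24 log units; within the scatter), so the result seen with compound 2 is not confined to the 4-bromophenyl group. The step from the cyclopentyl amine points the same way, with an at least 4.6-fold lower number from compound 1 to compound 4 (0.67 log units; beyond the scatter), and among the compounds shown, compound 2 and compound 4, which carry an aromatic ring on the amine nitrogen, give numbers, while compound 1 and compound 3, which carry none there, give only limits.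

The compounds shown leave open whether the aromatic ring or the amine hydrogen matters more at this position, a question that a benzylamino group or a methyl(phenyl)amino group could help to separate. They also do not show how far the true values of compound 1 and compound 3 lie beyond their limits, so the steps from those two compounds give only minimum sizes.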